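This account rests on a few compounds, and the source may have more. Where it says the series, first, only, none or still open, it means among the compounds named here.

Measured compounds in an assay on isolated protein with Bile acid receptor (Homo sapiens) as the target; a higher number here means that more compound is needed for the effect, a lower number that less compound is needed:
- compound 1, `COC(=O)/C=C/c1cccc(N(Cc2ccc(/C=C/c3c(F)cccc3F)cc2)C(=O)C(C)C)c1`: 108 nM
- compound 2, `COC(=O)/C=C/c1cccc(N(Cc2ccc(-c3cccc(Cl)c3)cc2)C(=O)C2CCCCC2)c1`: 94 nM
- compound 3, `COC(=O)/C=C/c1cccc(N(Cc2ccc(-c3cccc(Cl)c3)cc2)C(=O)C(C)C)c1`: 77 nM

The three numbers sit close together. Compound 2 gives 94 nM and stands second highest of the three; compound 1 is nearest with a slightly higher number and compound 3 a little lower, both gaps within the scatter. The two measured steps agree with that picture: a 1.4-fold lower number from compound 1 to compound 3 (0.15 log units; within the scatter) and a 1.2-fold lower number from compound 2 to compound 3 (0.09 log units; within the scatter), neither beyond the scatter, so swapping the distal aryl for the extended ethenyl group, or the cyclohexyl for isopropyl on the carbonyl, changes little.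

Compound 4, `COC(=O)/C=C/c1cccc(N(Cc2ccc(C(C)(C)C)cc2)C(=O)C2CCCCC2)c1`, is not yet measured. It differs from compound 2 at one place: tert-butyl in place of 3-chlorophenyl on an aromatic carbon. Among the measured compounds shown here, no measured step covers this kind of exchange; the only step at the same place, from compound 1 to compound 3, moves between two groups that both carry a six-membered aromatic ring, while here the ring is lost and a tert-butyl of four carbons enters. That step gives no direct guidance, and the shared core with its cyclohexyl carbonyl is kept from compound 2.

For the measured compounds named here, with no comparable precedent, a modest loss is expected for compound 4, estimated at 280 nM with a range of 90 nM to 900 nM, which means an expected step of a 3.0-fold higher number from compound 2 to compound 4 (0.47 log units; beyond the scatter).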

Compound 4, half-maximal effective concentration: > 1000 nM
Compound 4 was reported as a limit (the forecaster's own chance of this, stated with the estimate: 3%); at least 3.5-fold (0.55 log units) between middle value and limit.
By their numbers in this assay, from the lowest: compounds 3, 2 and 1 (each within the scatter of the next). At a limit, above all of these: compound 4.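

In this assay compound 4 is reported only as a limit, > 1000 nM. The earlier exchange on this aromatic carbon, a 1.4-fold lower number from compound 1 to compound 3 (0.15 log units; within the scatter), suggested that the group there could vary freely, but the new step, an at least 10-fold higher number from compound 2 to compound 4 (1.02 log units; beyond the scatter), shows that the position is not indifferent to what it carries, and this step is larger than any other shown for the series. Compound 1, compound 2 and compound 3 all keep a six-membered aromatic ring in the group at this place and lie within the scatter of each other, whereas compound 4, with tert-butyl and no ring there, stands alone at the limit: the limit of > 1000 nM in this assay, at which 1 of the 4 values shown sits.

Among the compounds shown here, the single exchange removes the aromatic ring, the chlorine and part of the heavy-atom count together, so it cannot show which of these matters; a plain phenyl or a cyclohexyl at this place would help separate them. From the compounds shown here alone, it also remains open whether tert-butyl behaves the same way with isopropyl on the carbonyl in place of cyclohexyl, and whether a carboxylic acid in place of the methyl ester would shift the whole set.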